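This account rests on a few compounds, and the source may have more. Where it says the series, first, only, none or still open, it means among the compounds named here.

Measured compounds:
- compound 1, `COc1cc(/C=C/C(=O)C2=C(/C=C/c3ccc(O)c(OC)c3)NC(=O)NC2c2ccccc2O)ccc1O`: 80.9%
- compound 2, `COc1cc(/C=C/C(=O)C2=C(/C=C/c3ccc(O)c(OC)c3)NC(=S)NC2c2ccc(C)cc2)ccc1O`: 30%

The account follows the step from compound 2 to compound 3. In a functional assay, with a stated time of 20 min, tested at 20 uM (on this read-out lower numbers stand for a weaker effect and higher numbers for a stronger effect at the one concentration tested), compound 2 gives 30%, the lower of the two numbers shown. Compound 1 gives 80.9% in this assay, a figure well beyond the scatter above compound 2; the two structures differ in more than one place, so nothing is said here about what separates them beyond the two values themselves.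

Compound 3, `COc1cc(/C=C/C(=O)C2=C(/C=C/c3ccc(O)c(OC)c3)NC(=S)NC2c2ccc(N(C)C)cc2)ccc1O`, has not yet been measured. It differs from compound 2 in one place: dimethylamino in place of methyl on an aromatic carbon. Within the data shown here, no single-change step between measured compounds is available to gauge the size of such a move, so the expectation rests on compound 2 alone. A step of modest size, if any, is expected in this assay, most likely upward, but a result within the scatter of compound 2 is also plausible. The expected step is a number 8 percentage points higher from compound 2 to compound 3 (within the scatter). Compound 3 is therefore estimated to give about 38% in this assay, within a range from 15% to 65%.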

Compound 3, a percentage reported as activity, at one concentration (the size of the read-out at that concentration, not a potency): 72.1%
Compound 3: the middle estimate sits 34.1 percentage points below what was measured; measured number outside the range, above it.
By their numbers in this assay, from the lowest: compound 2; then compounds 3 and 1 (each within the scatter of the next).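

In this assay the change from 4-methylphenyl to 4-(dimethylamino)phenyl gives a number 42.1 percentage points higher from compound 2 to compound 3 (beyond the scatter) and so shows that this position, on an aromatic carbon para to a large group, is not indifferent: with the rest of the structure held fixed, the read-out responds strongly to what sits there. Among these compounds, compound 1 and compound 2 differ in more than one place and could not show this, whereas compound 2 and compound 3 form the first single-change pair here, and its step is large. No supporting data bear on why dimethylamino in place of methyl has this effect.

The compounds shown leave open whether the step is particular to dimethylamino or would also appear with a primary amine, a diethylamino group or a methoxy group at the same place. They also leave open whether the same change would carry over to the core of compound 1, which has oxygen where compound 2 and compound 3 have sulfur.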